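The source may report more compounds than this note shows. Statements on the series, on what has been measured and on what is new or still open speak of the compounds shown alone.

Compound 2 `Cc1ccc(NC(=O)c2ccc(CNCCN(C)C)cc2)cc1Nc1nccc(-c2cccnc2)n1` is the starting point of this step. In an ADME assay on BaF3 cells (Mus musculus) for cytotoxicity, read by CellTiter-Glo and CCK-8 assay, with a stated time of 72 h (a higher number here means a weaker inhibitor of growth, a lower number a stronger inhibitor of growth), compound 2 gives > 10000 nM, which is a limit of the assay and not a number. Compound 1 `CCC(=O)Nc1cc(C(=O)Nc2ccc(C)c(Nc3nccc(-c4cccnc4)n3)c2)cc(C(F)(F)F)c1` is measured in the same way. In this assay compound 1 gives > 10000 nM, again a limit rather than a number. Compound 3 `Cc1ccc(NC(=O)c2ccc(CN(CCN(C)C)C(=O)c3cccs3)cc2)cc1Nc1nccc(-c2cccnc2)n1` carries a (thiophen-2-yl)carbonyl in place of hydrogen on an amine nitrogen relative to compound 2. In this assay compound 3 gives > 10000 nM, once more a limit. The step that the two limits leave unreadable from compound 2 to compound 3 is consequently one that the two limits leave unreadable.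

Compound 4 `C=CC(=O)N(CCC(C)C)Cc1ccc(C(=O)Nc2ccc(C)c(Nc3nccc(-c4cccnc4)n3)c2)cc1` differs from compound 2 by isopentyl(vinylcarbonyl)amino in place of (2-(dimethylamino)ethyl)amino on a saturated chain carbon bound to an aromatic carbon. Within the data shown here, no measured step bears directly on this change, and the one comparison available, a step that the two limits leave unreadable from compound 2 to compound 3, has no readable size. What can be said is the limit of > 10000 nM in this assay, at which 3 of the 3 values shown sit. The expectation is accordingly a step of no size beyond the scatter, a step that the limit leaves unreadable from compound 2 to compound 4. Compound 4 is expected to give 15000 nM in this assay, within a range from 5000 nM to 50000 nM, most likely reported only as a limit.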

Compound 4, concentration for 50% growth inhibition: 5620 nM
Estimate against measurement, compound 4: 2.7-fold (0.43 log units) above, and the stated range covers the measured number.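

In this assay compound 4 is the first compound shown to give a number and not a limit, which makes this saturated chain carbon bound to an aromatic carbon a place where a change can produce a readable value: the limit of > 10000 nM in this assay, at which 3 of the 4 values shown sit. Isopentyl(vinylcarbonyl)amino in place of (2-(dimethylamino)ethyl)amino gives an at least 1.7-fold lower number from compound 2 to compound 4 (0.25 log units; that floor lies within the scatter). Compound 2 stands at a limit, so this is only a floor on the step, and the other step from compound 2, to compound 3, cannot be read.

The isopentyl chain and the vinylcarbonyl enter together, and the compounds shown do not separate them. On these data alone, how an acetyl in place of the vinylcarbonyl, or an ethyl chain in place of the isopentyl, would read in this assay stays open.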